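The compounds below may be only part of what the source reports. "The series", "measured", "known", "first", "only" and "open" are said of these compounds alone.

Measured so far:
compound 1 `Cc1cc(Cl)nc(NCCCCCCNc2ccnc3cc(Cl)ccc23)n1`: 49400 nM
compound 2 `Cc1cc(Cl)nc(NCCNc2ccnc3cc(Cl)ccc23)n1`: 43000 nM

Both values come from an ADME assay on Vero cells (Chlorocebus sabaeus) for cytotoxicity, read by neutral red uptake, with a stated time of 48 h; a lower number here means a stronger inhibitor, a higher number a weaker inhibitor. Compound 1 stands level with compound 2, as the two numbers lie within the usual scatter of each other.

Compound 3 `Cc1cc(NCCCCCCNc2ccnc3cc(Cl)ccc23)nc(Cl)n1` has not yet been measured. It has the same atoms as compound 1, joined differently, with 2-chloro-6-methylpyrimidin-4-yl in place of 4-chloro-6-methylpyrimidin-2-yl on an amine nitrogen. Going by the values given here, no measured pair shows this change, so the data offer no direct guide to it. In this assay, no step beyond the scatter is expected, and neither direction is favoured. The estimate is an expected step of a 1.2-fold lower number from compound 1 to compound 3 (0.07 log units; within the scatter). For compound 3 the estimated value is 42000 nM, with an expected range of 15000 nM to 100000 nM.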

Compound 3, half-maximal inhibitory concentration: 32700 nM
Estimate against measurement, compound 3: 1.3-fold (0.11 log units) above; the range from low to high includes it.
By their numbers in this assay, from the lowest: compounds 3, 2 and 1 (each within the scatter of the next).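

Going by these compounds alone, the first matched step concerns this exchange on the amine nitrogen: in this assay, 2-chloro-6-methylpyrimidin-4-yl in place of 4-chloro-6-methylpyrimidin-2-yl gives a 1.5-fold lower number from compound 1 to compound 3 (0.18 log units; within the scatter), so this read-out does not separate the two arrangements of the same atoms in this pair. The result holds for this one pair only, and compound 2 carries no matching exchange. No measurement on hand bears on why the two arrangements read alike.

From the compounds shown here alone, whether the same exchange stays within the scatter with the chain of compound 2 remains open. Also open, going by these compounds, is whether a morpholine or a dimethylamino group in place of the chlorine on either pyrimidine would give a step beyond the scatter.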